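The source may report more compounds than this note shows. Statements on the series, on what has been measured and on what is new or still open speak of the compounds shown alone.

Measured so far:
compound 1 `COc1cc2c(Oc3ccc(NC(=O)c4cn(-c5ccccc5)nn4)cc3F)ccnc2cc1OCCCN1CCCC1`: 280 nM
compound 2 `COc1cc2c(Oc3ccc(NC(=O)c4cn(-c5ccccc5Cl)nn4)cc3F)ccnc2cc1OCCCN1CCCC1`: 190 nM

In a functional assay on NCI-H460 cells (Homo sapiens) for cytotoxicity, read by MTT assay, with a stated time of 72 h (a higher number here means a weaker inhibitor, a lower number a stronger inhibitor), compound 2 gives the lowest of the two numbers, with compound 1 nearest; the step of a 1.5-fold lower number from compound 1 to compound 2 (0.17 log units; within the scatter) is within the scatter. Compound 3 `COc1cc2c(Oc3ccc(NC(=O)c4cn(-c5ccccc5C)nn4)cc3F)ccnc2cc1OCCCN1CCCC1` differs from compound 2 by methyl in place of chloro on an aromatic carbon. Within the data shown here, the one measured step that bears on this, a 1.5-fold lower number from compound 1 to compound 2 (0.17 log units; within the scatter), changed the same aromatic carbon and stayed within the scatter, so no step beyond the scatter is expected in this assay; the expected step is a 1.2-fold higher number from compound 2 to compound 3 (0.06 log units; within the scatter). For compound 3 the estimate in this assay is 220 nM, range 100 nM to 480 nM.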

Compound 3, half-maximal inhibitory concentration: 1260 nM
Beside the measured number, compound 3's estimate is 5.7-fold (0.76 log units) below it; the whole stated range lies below it.
By their numbers in this assay, from the lowest: compounds 2 and 1 (each within the scatter of the next); then compound 3.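

In this assay this aromatic carbon turns out not to be indifferent to what it carries: methyl gives a 6.6-fold higher number from compound 2 to compound 3 (0.82 log units; beyond the scatter) and also a 4.5-fold higher number from compound 1 to compound 3 (0.65 log units; beyond the scatter) while chloro and hydrogen remain within the scatter of each other. Chloro and methyl, each of one heavy atom, therefore part clearly here, with compound 3 standing apart from both others. No measurement on hand accounts for this difference.

From the compounds shown here alone, whether groups such as methoxy, an amine or a carboxylic acid at this carbon would read like chloro or like methyl stays open. Also open, going by these compounds, is whether methyl would give a similar step on the other carbons of that ring.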